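The compounds below may be only part of what the source reports. "The series", "measured", "known", "first", "only" and "open" are said of these compounds alone.

Measured so far in a functional assay on the whole organism with Mus musculus as the target, in the maximal electroshock model, with a stated time of 120 min; a lower number here means that less compound is needed, a higher number that more compound is needed for the effect:
compound 1 `CCCCCCCCCc1cccc(N2CCNCC2)n1`: compound 1 gives 10 mg/kg
compound 2 `CCCCCCc1cccc(N2CCNCC2)n1`: compound 2 gives 10 mg/kg
compound 3 `CCCCCCCCCCc1cccc(N2CCNCC2)n1`: compound 3 gives 30 mg/kg

Compound 2 stands level with compound 1; together they hold the lowest number of the three. Against compound 3 there is a 3.0-fold higher number from compound 2 to compound 3 (0.48 log units; beyond the scatter). These three compounds differ only in the length of the chain on the shared core: no change at the digits printed from compound 1 to compound 2 (within the scatter), while a 3.0-fold higher number from compound 1 to compound 3 (0.48 log units; beyond the scatter). A shorter chain therefore left the dose unchanged within the scatter, and a longer chain raised it modestly.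

Compound 4 `CCCCSc1cccc(N2CCNCC2)n1` carries butylsulfanyl in place of hexyl on an aromatic carbon. The measured steps bear on this change only in part. Within the data shown here, the chain in compound 4 is shorter than the hexyl of compound 2, and the one shortening step seen so far stayed within the scatter. Among the measured compounds shown here, no measured step introduces a sulfur, so that part of the change is untested, and the range for compound 4 must stay wide. The expected step is no change at the digits printed from compound 2 to compound 4 (within the scatter), with no change beyond the scatter. Compound 4 is estimated at 10 mg/kg, with a range from 5 mg/kg to 30 mg/kg.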

Compound 4, minimum effective dose: 100 mg/kg
For compound 4 the middle estimate is 10-fold (1.00 log units) below the measured one; measured number outside the range, above it.
By their numbers in this assay, from the lowest: compounds 1 and 2 (each within the scatter of the next); then compound 3; then compound 4.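

In this assay, putting butylsulfanyl in place of hexyl on this aromatic carbon, next to the ring nitrogen, gives a 10-fold higher number from compound 2 to compound 4 (1.00 log units; beyond the scatter), even though the entering group has 5 heavy atoms against 6 for hexyl. This step is larger than the largest change seen among the all-carbon chains, a 3.0-fold higher number from compound 2 to compound 3 (0.48 log units; beyond the scatter), so a similar atom count does not guarantee a similar dose at this position. No measurement here bears on why the dose rises.

The step changes two things at once, bringing in a sulfur and altering the chain, and the compounds shown cannot separate these two parts. A pentyl chain, with a carbon where the sulfur sits, would test the effect of the sulfur alone, while a butoxy group, with an oxygen in that place, would show whether the rise is particular to sulfur or also appears with another atom linking the chain to the aromatic carbon.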